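This account rests on a few compounds, and the source may have more. Where it says the series, first, only, none or still open, it means among the compounds named here.

Measured compounds in a functional assay on NCI-H23 cells (Homo sapiens) for inhibition, read by sulforhodamine B assay, with a stated time of 48 h; on this read-out lower numbers stand for stronger inhibition of growth and higher numbers for weaker inhibition of growth:

Compound 1 `O=C(Nc1cccc(-n2cc(-c3ccncc3)c(-c3ccc(Cl)c(O)c3)n2)c1)Nc1ccc(Cl)c(Cl)c1` gives 29100 nM.
Compound 2 `COc1cc(-c2nn(-c3cccc(NC(=O)c4ccc(Cl)c(C(F)(F)F)c4)c3)cc2-c2ccncc2)ccc1Cl` reaches only the limit of the assay, > 32500 nM.

Compound 2 therefore has no number of its own in this assay, only a limit: the limit of > 32500 nM in this assay, at which 1 of the 2 values shown sits. Of the two measured compounds it is the one whose growth inhibition could not be pinned to a value, while compound 1 did give a number. Both compounds show weak inhibition of growth on this read-out.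

The step of interest leads from compound 2 to compound 3 `COc1cc(-c2nn(-c3cccc(NC(=O)c4cccc(C(F)(F)F)c4)c3)cc2-c2ccncc2)ccc1Cl`, a change confined to one aromatic carbon: hydrogen in place of chloro on an aromatic carbon. Everything else in the molecule, including the shared core of compound 2, stays the same.

Going by the values given here, no measured pair in this set shares such a change, so nothing here shows how losing a chloro at that place shifts the read-out. The expectation is that the step in this assay stays within the usual scatter, with no clear direction, which is the meaning of the estimated step that the limit leaves unreadable from compound 2 to compound 3. Compound 3 is expected to give about 35000 nM, with a range from 15000 nM to 80000 nM, and quite possibly only a limit again.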

Compound 3, concentration for total growth inhibition: 32500 nM
Beside the measured number, compound 3's estimate is 1.1-fold (0.03 log units) above it; low and high end bracket the measured number.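

Compound 2 in this assay has only a limit, given as > 32500 nM and not as a number. With hydrogen in place of the chloro, compound 3 gives 32500 nM as an actual number, so the 3-(trifluoromethyl)phenyl form still yields a measurable value without that chloro, although growth inhibition remains weak. In this assay this change reads as a number no higher from compound 2 to compound 3 (the limit leaves the size open). The size of this step cannot be read because one end of it is only a limit: the limit of > 32500 nM in this assay, at which 1 of the 3 values shown sits.

The compounds shown leave open how an amine or a carboxylic acid on that same aromatic carbon would read in this assay and whether any such group would bring a clearly stronger inhibition of growth. They also leave open what the trifluoromethyl group contributes, since it stays in place across this step.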